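A few compounds are considered here, and "the series" means these few. Any claim that something is new, unique, unknown or untested is made for them only; others in the source may bear on it.

Going by the values given here, compound 2 `N#Cc1ccc(-c2nc3sccn3c2/C=N/OCc2ccc(Cl)c(Cl)c2)cc1` holds the lower of the two numbers measured so far. In an assay on HepG2 cells for agonist activity at nuclear receptor subfamily 1 group I member 3 (Homo sapiens), read by a luciferase reporter, with a stated time of 23 h (a higher number here means that more compound is needed for the effect, a lower number that less compound is needed), compound 2 gives 3400 nM. Compound 1 `CC(C)(C)c1ccc(CO/N=C/c2c(-c3ccc4ccccc4c3)nc3occn23)cc1` gives 7900 nM in this assay, a number that lies beyond the usual scatter above that of compound 2; the two compounds differ in more than one place, so the gap cannot be tied to any single change. Compound 3 `COc1ccc(-c2nc3sccn3c2/C=N/OCc2ccc(Cl)c(Cl)c2)cc1` has not yet been measured in this assay. It differs from compound 2 in one place: methoxy in place of cyano on an aromatic carbon. The cyano group leaves and a methoxy group enters on an aromatic carbon of a six-membered aromatic ring of carbon only, para to a large group. Among the compounds with values here, no measured pair here isolates such a swap, so there is no step to lean on. The expected change is a 1.3-fold higher number from compound 2 to compound 3 (0.12 log units; within the scatter), a small one that stays within the scatter. Compound 3 is estimated to give about 4500 nM, within a range from 1500 nM to 14000 nM.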

Compound 3, half-maximal effective concentration: 490 nM
Compound 3: the middle estimate sits 9.2-fold (0.96 log units) above what was measured; measured number below the stated range.
By their numbers in this assay, from the lowest: compound 3; then compound 2; then compound 1.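

Going by these compounds alone, this is the first pair that differs in one place only, so the position on the six-membered aromatic ring of carbon only, para to a large group, can now be read on its own in this assay. Replacing 4-cyanophenyl with 4-methoxyphenyl gives a 6.9-fold lower number from compound 2 to compound 3 (0.84 log units; beyond the scatter) and so shows that this position is sensitive to the group it carries, even though both groups have the same printed counts of heavy atoms and hydrogen-bond acceptors. No measurement here explains the difference between the two groups.

As far as these compounds go, it remains open whether the lower number is particular to methoxy or would also appear with an amine, a hydroxyl group or a longer chain such as ethoxy at this position. From the compounds shown here alone, it is also open whether the same swap would have a similar effect on the core of compound 1.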